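A few compounds are considered here, and "the series" means these few. Any claim that something is new, unique, unknown or untested is made for them only; others in the source may bear on it.

Among the measured compounds shown here, compound 1 `COc1ccc(S(=O)(=O)N2CCc3cccc(-c4ccc(F)cc4)c32)cc1` gives 94.6 nM in a functional assay on KB-VIN10 cells (Homo sapiens) for inhibition, with a stated time of 72 h (a lower number here means a stronger inhibitor, a higher number a weaker inhibitor), the lower of the two numbers measured so far. Compound 2 `COc1ccc(S(=O)(=O)n2ccc3cccc(-c4ccc(F)cc4)c32)cc1` gives 202 nM in this assay, and this gap lies beyond the usual scatter. Compound 3 `COc1ccc(S(=O)(=O)N2CCc3cccc(-c4ccc(F)c(F)c4)c32)cc1` has not yet been measured; it differs from compound 1 by fluoro in place of hydrogen on an aromatic carbon. For the measured compounds named here, no measured pair shows this change, so the expected step is a 1.1-fold lower number from compound 1 to compound 3 (0.02 log units; within the scatter), which does not go beyond the scatter in either direction. Compound 3 is therefore estimated at 90 nM in this assay, with a likely range from 40 nM to 220 nM.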

Compound 3, half-maximal inhibitory concentration: 46 nM
The estimate for compound 3 lay 2.0-fold (0.29 log units) above the measured number; the range from low to high includes it.
By their numbers in this assay, from the lowest: compound 3; then compound 1; then compound 2.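

Replacing 4-fluorophenyl with 3,4-difluorophenyl gives a 2.1-fold lower number from compound 1 to compound 3 (0.31 log units; beyond the scatter) in this assay. This position, ortho to a fluoro group, therefore accepts a second fluoro, and the number falls rather than rises, which compound 1 and compound 2 alone could not show. Nothing available explains this modest step. On these data alone, it remains open whether a chloro group, a methoxy group or an amine at this position would lower the number further, and whether the same fluoro change would act similarly on the core of compound 2.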